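The source may hold more compounds than are shown below. What is called first, only, known or untested is meant among the compounds shown, and "the series" means these compounds.

Compound 1 `Nc1ncnn2c([C@@H]3O[C@H](CO)[C@@H](O)[C@H]3O)cc(C#Cc3ccc(F)cc3)c12` gives 55400 nM in a functional assay on CAPAN-1 cells (Homo sapiens) for antiproliferative activity, with a stated time of 72 h; a lower number here means a stronger inhibitor, a higher number a weaker inhibitor.
Compound 2 `Nc1ncnn2c([C@@H]3O[C@H](CO)[C@@H](O)[C@H]3O)cc(C#Cc3cccs3)c12` gives 32000 nM in this assay.
Compound 3 `Nc1ncnn2c([C@@H]3O[C@H](CO)[C@@H](O)[C@H]3O)cc(-c3ccc(Cl)cc3)c12` gives 56700 nM in this assay.

Compound 3 sits at the upper end of these three numbers, but the step of a 1.0-fold higher number from compound 1 to compound 3 (0.01 log units; within the scatter) and the step of a 1.8-fold higher number from compound 2 to compound 3 (0.25 log units; within the scatter) both lie within the usual scatter, so the three compounds cannot be told apart on these data. Compound 4 `Cc1ccccc1-c1cc([C@@H]2O[C@H](CO)[C@@H](O)[C@H]2O)n2ncnc(N)c12` is not yet measured. It differs from compound 3 in one place: 2-methylphenyl in place of 4-chlorophenyl on an aromatic carbon. Among the compounds with values here, no measured step swaps one substituted phenyl group for another directly on the aromatic carbon; the closest steps are those bringing 4-chlorophenyl in for the ethynyl-linked groups, a 1.0-fold higher number from compound 1 to compound 3 (0.01 log units; within the scatter) and a 1.8-fold higher number from compound 2 to compound 3 (0.25 log units; within the scatter), and each stayed within the scatter. With three changes at this position all leaving the number essentially unmoved, no step beyond the scatter is expected in this assay, in either direction. The estimated step is a 1.1-fold lower number from compound 3 to compound 4 (0.05 log units; within the scatter). Compound 4 is therefore expected to give about 50000 nM, within a range from 20000 nM to 125000 nM.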

Compound 4, half-maximal inhibitory concentration: 97500 nM
The estimate for compound 4 lay 2.0-fold (0.29 log units) below the measured number, within the range that was stated.
By their numbers in this assay, from the lowest: compounds 2, 1, 3 and 4 (each within the scatter of the next, the first and the last beyond it).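

At the aromatic carbon of the five-membered ring, this assay now gives its first step beyond the scatter: a 3.0-fold higher number from compound 2 to compound 4 (0.48 log units; beyond the scatter), a modest step that comes with 2-methylphenyl in place of 2-(thiophen-2-yl)ethynyl. The other two steps, a 1.7-fold higher number from compound 3 to compound 4 (0.24 log units; within the scatter) and a 1.8-fold higher number from compound 1 to compound 4 (0.25 log units; within the scatter), stay within the scatter, so neither replacing 4-chlorophenyl nor replacing 2-(4-fluorophenyl)ethynyl with 2-methylphenyl can be read as a real change. Within the data shown here, nothing measured here explains the one larger step.

On these data alone, all four compounds carry a carbon-only aromatic ring at this position, whether attached directly or through a triple bond, so it remains open how a group without such a ring would behave there. An amine, a carboxylic acid or a longer saturated carbon chain would test this.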